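Cyclopropyl to propyl on the amine-bound carbon

A few compounds are considered here, and "the series" means these few. Any claim that something is new, unique, unknown or untested is made for them only; others in the source may bear on it.

compound 1 `CCCN(Cc1ccc(OCCN2C(=O)CCC2=O)c(C)c1)C1c2ccc(Cl)cc2CC1C(=O)O`: 1350 nM
compound 2 `Cc1cc(CN(CC2CC2)C(CC(=O)O)c2ccc(Cl)cc2)ccc1OCCn1c(=O)ccn(C)c1=O`: 91 nM
compound 3 `COc1cc(CN(CC2CC2)C(CC(=O)O)c2ccc(Cl)cc2)ccc1OCCn1c(=O)ccn(C)c1=O`: 91 nM

In an assay on CHO cells for displacement of a labelled ligand from C-X-C chemokine receptor type 3 (Homo sapiens), with a stated time of 60 min (on this read-out lower numbers stand for stronger inhibition and higher numbers for weaker inhibition), compound 3 stands level with compound 2 at the digits shown, the two together giving the lowest numbers of the three, while compound 1 sits furthest away with a higher number, beyond the scatter. Among the measured compounds shown here, the one single-point step measured, no change at the digits printed from compound 2 to compound 3 (within the scatter), concerns the aromatic substituent and not the amine. Compound 4 `CCCCN(Cc1ccc(OCCn2c(=O)ccn(C)c2=O)c(OC)c1)C(CC(=O)O)c1ccc(Cl)cc1` differs from compound 3 by propyl in place of cyclopropyl on a saturated chain carbon bound to an amine nitrogen. For the measured compounds named here, no measured pair isolates this change; compound 1 also carries propyl on the nitrogen but differs in several other places, so its value speaks only for itself. The step of a 1.2-fold higher number from compound 3 to compound 4 (0.08 log units; within the scatter) is therefore expected to stay within the scatter. Compound 4 is estimated at 110 nM, with a range from 40 nM to 320 nM in this assay.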

Compound 4, half-maximal inhibitory concentration in the C-X-C chemokine receptor type 3 assay: 69 nM
For compound 4 the middle estimate is 1.6-fold (0.20 log units) above the measured one, and the stated range covers the measured number.
By their numbers in the C-X-C chemokine receptor type 3 assay, from the lowest: compounds 4, 2 and 3 (each within the scatter of the next); then compound 1.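

Among the compounds shown here, in the C-X-C chemokine receptor type 3 assay, compound 3 gives 91 nM and compound 4 gives 69 nM: propyl in place of cyclopropyl on a saturated chain carbon bound to an amine nitrogen gives a 1.3-fold lower number from compound 3 to compound 4 (0.12 log units; within the scatter), so at this position the three-membered ring can open to a chain with no change beyond the scatter, which no earlier pair could show. In a physicochemical assay for solubility, at pH 1.1 (on this read-out lower numbers stand for lower solubility and higher numbers for higher solubility), compound 3 gives 3000000 nM and compound 4 gives 3000000 nM, and the same change gives no change at the digits printed from compound 3 to compound 4 (within the scatter) as well. Nothing measured here offers an explanation for either result.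

As far as these compounds go, whether a longer chain such as pentyl, or a chain carrying an amine or a hydroxyl group, would fare the same at this position in the C-X-C chemokine receptor type 3 assay remains open. So does whether this change would read alike on compound 2, which carries methyl where compound 3 carries methoxy.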